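Moving the bromine from the 3- to the 4-position of the phenyl ring

A few compounds are considered here, and "the series" means these few. Any claim that something is new, unique, unknown or untested is made for them only; others in the source may bear on it.

Three members of the shared core have been measured in an assay for inhibition of alkaline phosphatase, tissue-nonspecific isozyme (Homo sapiens), read by spectrophotometry, with stated times of 10 min and 20 min; on this read-out higher numbers stand for weaker inhibition and lower numbers for stronger inhibition. Compound 1 `COc1ccc(/C=C2\NS(=O)(=O)c3ccccc3C2=O)cc1` gives 4040 nM in this assay. Compound 2 `O=C1/C(=C/c2ccccc2Br)NS(=O)(=O)c2ccccc21` reaches only the limit of > 200000 nM in this assay. Compound 3 `O=C1/C(=C/c2cccc(Br)c2)NS(=O)(=O)c2ccccc21` likewise reaches only the limit of > 200000 nM in this assay. Compound 3 therefore stands at the limit, together with one other value, as summarised in the limit of > 200000 nM in this assay, at which 2 of the 3 values shown sit. Within the data shown here, the one step between measured compounds, a step that the two limits leave unreadable from compound 2 to compound 3, cannot be read because both ends are limits.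

Compound 4 `O=C1/C(=C/c2ccc(Br)cc2)NS(=O)(=O)c2ccccc21` is not yet measured. The change from compound 3 is 4-bromophenyl in place of 3-bromophenyl on a double-bonded chain carbon bound to a double-bonded ring carbon. Among the measured compounds shown here, no measured step bears directly on it; the only related observation is that compound 1, which also carries its group in the 4-position, gives a number rather than a limit in this assay. Compound 4 is therefore expected to come in at about 60000 nM, between 8000 nM and 200000 nM, a step of an at least 3.3-fold lower number from compound 3 to compound 4 (0.52 log units; beyond the scatter) that is estimated with considerable uncertainty.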

Compound 4, half-maximal inhibitory concentration: 1430 nM
Estimate against measurement, compound 4: 42-fold (1.62 log units) above; the measured number lies below the stated range.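

In this assay, the place of the bromine on the phenyl ring separates a measurable number from a limit: 4-bromophenyl gives an at least 130-fold lower number from compound 3 to compound 4 (2.14 log units; beyond the scatter), and in place of 2-bromophenyl it gives an at least 130-fold lower number from compound 2 to compound 4 (2.14 log units; beyond the scatter). Compound 2 and compound 3 remain at a limit of the assay: the limit of > 200000 nM in this assay, at which 2 of the 4 values shown sit. Bromo in place of methoxy on an aromatic carbon gives only a 2.8-fold lower number from compound 1 to compound 4 (0.45 log units; beyond the scatter), a much smaller step than those from moving the bromine.

Going by these compounds, what a 4-chlorophenyl, 4-aminophenyl or 4-carboxyphenyl group would give on the double-bonded chain carbon remains open. Also open, on these data alone, is whether 3-methoxyphenyl or 2-methoxyphenyl would reach a limit as the matching bromophenyl compounds do, or would keep a measurable number.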